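Shortening the Heptyl Chain of Compound 2

The compounds below may be only part of what the source reports. "The series", "measured", "known", "first", "only" and "open" are said of these compounds alone.

Three measured compounds share one core and differ only in the group on an aromatic carbon of that core. Compound 1 `COc1nc2ccc(Br)cc2cc1C(c1ccccc1)n1cc(C2CC2)nn1` gives -5.84% in an ADME assay on HeLa cells (Homo sapiens) for cytotoxicity, read by sulforhodamine B assay, with a stated time of 48 h, tested at 10 uM; a higher number here means more inhibition at the concentration tested (going by the name of the read-out), a lower number less inhibition. Compound 2 `CCCCCCCc1cn(C(c2ccccc2)c2cc3cc(Br)ccc3nc2OC)nn1` gives 9.7% in this assay, and compound 3 `COc1nc2ccc(Br)cc2cc1C(c1ccccc1)n1cc(CCCO)nn1` gives 11.3%. Compound 2 stands second highest of the three numbers: it lies within the scatter of compound 3, while the step of a number 15.5 percentage points higher from compound 1 to compound 2 (beyond the scatter) lies beyond it. Compound 4 `CCCc1cn(C(c2ccccc2)c2cc3cc(Br)ccc3nc2OC)nn1` differs from compound 2 by hydrogen in place of butyl on a saturated chain carbon, three bonds along the chain from an aromatic carbon. Among the compounds with values here, no measured step shortens a chain without adding another group; the nearest guide is a number 1.6 percentage points higher from compound 2 to compound 3 (within the scatter), where a change at this same place stayed within the scatter. A step within the scatter is therefore expected, a number 4.7 percentage points lower from compound 2 to compound 4 (within the scatter). Compound 4 is expected to give 5%, between -10% and 20%.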

Compound 4, a percentage reported as inhibition, at one concentration (the size of the read-out at that concentration, not a potency): -2.25%
Compound 4: the middle estimate sits 7.3 percentage points above what was measured, and the stated range covers the measured number.
By their numbers in this assay, from the lowest: compounds 1 and 4 (each within the scatter of the next); then compounds 2 and 3 (each within the scatter of the next).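

Cutting heptyl down to propyl gives a number 12 percentage points lower from compound 2 to compound 4 (beyond the scatter) in this assay, so unlike the earlier change at this place, losing butyl here does move the number. Hydrogen in place of hydroxy gives a number 13.6 percentage points lower from compound 3 to compound 4 (beyond the scatter) and propyl in place of cyclopropyl gives a number 3.6 percentage points higher from compound 1 to compound 4 (within the scatter), so among these compounds propyl sits with cyclopropyl, apart from heptyl and 3-hydroxypropyl. Nothing available explains these differences. Going by these compounds, what a butyl or pentyl chain would give stays open, as does an amine in place of the hydroxy.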